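A few compounds are considered here, and "the series" means these few. Any claim that something is new, unique, unknown or untested is made for them only; others in the source may bear on it.

Measured in a functional assay on SK-OV-3 cells (Homo sapiens) for antiproliferative activity, read by MTT assay, with a stated time of 72 h; on this read-out lower numbers stand for stronger inhibition and higher numbers for weaker inhibition
- compound 1 `O=C(CCc1cccc2c1B(O)OC2)Nc1cccc(-c2cccc(F)c2)c1` gives 480 nM
- compound 2 `O=C(CCc1cccc2c1B(O)OC2)Nc1cccc(-c2cccc(C(F)(F)F)c2)c1` gives 390 nM

Going by the values given here, compound 2 stands within the scatter of compound 1, the only other measured compound in this assay. Compound 3 `O=C(CCc1cccc2c1B(O)OC2)Nc1cccc(-c2ccc(C(F)(F)F)cc2)c1` differs from compound 2 on an aromatic carbon, meta to a large group: 4-(trifluoromethyl)phenyl in place of 3-(trifluoromethyl)phenyl on an aromatic carbon. Among the compounds with values here, the only measured step, a 1.2-fold lower number from compound 1 to compound 2 (0.09 log units; within the scatter), replaces one group with another and does not shift a group to another ring carbon. It therefore gives no direct measure of this change, and no shift beyond the scatter is expected. The expected step is a 1.2-fold higher number from compound 2 to compound 3 (0.06 log units; within the scatter). For compound 3 the estimate is 450 nM, with an expected range of 170 nM to 1200 nM.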

Compound 3, half-maximal inhibitory concentration: 500 nM
Estimate against measurement, compound 3: 1.1-fold (0.05 log units) below, within the range that was stated.
By their numbers in this assay, from the lowest: compounds 2, 1 and 3 (each within the scatter of the next).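

In this assay, 4-(trifluoromethyl)phenyl in place of 3-(trifluoromethyl)phenyl gives a 1.3-fold higher number from compound 2 to compound 3 (0.11 log units; within the scatter), the first measured shift of a group to another ring carbon in this series, and it lies within the scatter. Against the 3-fluorophenyl group, 4-(trifluoromethyl)phenyl gives a 1.0-fold higher number from compound 1 to compound 3 (0.02 log units; within the scatter), so this pair also cannot be told apart. No available evidence bears on this result. Open, going by these compounds, is whether an amine or a carboxylic acid in place of trifluoromethyl on this ring would give a step beyond the scatter.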